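Ethylamino in Place of (Dimethylamino)methyl on the Carbonyl

The source may hold more compounds than are shown below. What is called first, only, known or untested is meant among the compounds shown, and "the series" means these compounds.

Compound 1 `O=C(CN1CCCC1)N1CCC(NS(=O)(=O)c2cc(S(=O)(=O)c3ccccc3)ccc2C(F)(F)F)CC1`: 190 nM
Compound 2 `CN(C)CC(=O)N1CCC[C@H]1C(=O)N1CCC(NS(=O)(=O)c2cc(S(=O)(=O)c3ccccc3)ccc2C(F)(F)F)CC1`: 310 nM

Both compounds were tested in a functional assay on U2OS cells for antagonist activity at proto-oncogene Wnt-3 (Homo sapiens), read by a luciferase reporter, with a stated time of 18 h; on this read-out lower numbers stand for an effect already at smaller amounts and higher numbers for an effect only at larger amounts of compound. Compound 1 gives 190 nM and compound 2 gives 310 nM. Compound 2 holds the higher of the two numbers, but the step from compound 1 to compound 2, a 1.6-fold higher number from compound 1 to compound 2 (0.21 log units; within the scatter), stays within the scatter, so the two values show no real order. That step exchanged the group on the carbonyl attached to the piperidine, replacing (pyrrolidin-1-yl)methyl by 1-(((dimethylamino)methyl)carbonyl)pyrrolidin-2-yl.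

Compound 3 `CCNC(=O)N1CCC[C@H]1C(=O)N1CCC(NS(=O)(=O)c2cc(S(=O)(=O)c3ccccc3)ccc2C(F)(F)F)CC1` changes the same region once more: ethylamino in place of (dimethylamino)methyl on a carbonyl carbon. Among the measured compounds shown here, the only measured step that bears on this position is the one from compound 1 to compound 2, and it was small. On that basis no step beyond the scatter is expected in this assay from compound 2 to compound 3, in either direction; a change of roughly a 1.0-fold lower number from compound 2 to compound 3 (0.01 log units; within the scatter) is what the estimate implies. Compound 3 is therefore expected to give about 300 nM, with a likely range from 120 nM to 800 nM.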

Compound 3, half-maximal effective concentration: 90 nM
Compound 3: the middle estimate sits 3.3-fold (0.52 log units) above what was measured, and the stated range ends above it.
By their numbers in this assay, from the lowest: compound 3; then compounds 1 and 2 (each within the scatter of the next).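

In this assay, the group on the carbonyl carbon whose other neighbour is an amide-type nitrogen in a ring now proves able to shift the number: ethylamino in place of (dimethylamino)methyl gives a 3.4-fold lower number from compound 2 to compound 3 (0.54 log units; beyond the scatter), whereas the earlier step in this region stayed within the scatter. The 1-(ethylcarbamoyl)pyrrolidin-2-yl group also separates from the (pyrrolidin-1-yl)methyl group, with a 2.1-fold lower number from compound 1 to compound 3 (0.32 log units; beyond the scatter), so compound 3 holds the lowest number of the three and the larger pyrrolidine-bearing substituent is not in itself what sets the number. The change in this position therefore depends on what is attached to that carbonyl, not simply on the carbonyl being present, and the exchange takes out 1 hydrogen-bond acceptor and brings in 1 hydrogen-bond donor, although no measurement shown ties the shift to either count.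

From the compounds shown here alone, whether methylamino, propylamino or an ethoxy group on the same carbonyl carbon would follow ethylamino stays open. So does whether a dimethylamino group there, which has no amide hydrogen, would return the number to that of compound 2.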